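The source may report more compounds than this note shows. Statements on the series, on what has been measured and on what is new or still open speak of the compounds shown alone.

Measured compounds:
compound 1 `O=C1C(=O)N(CC(CO)NCCCNc2ccnc3cc(Cl)ccc23)c2ccccc21`, 2%
compound 2 `O=C1C(=O)N(CC(CO)NCCCNc2ccnc3cc(Cl)ccc23)c2ccc(Cl)cc21`, 0%
compound 3 `O=C1C(=O)N(CC(CO)NCCCCNc2ccnc3cc(Cl)ccc23)c2ccc(F)cc21`, -1%

In an ADME assay on HCT-116 cells (Homo sapiens) for cytotoxicity, read by MTT assay, with a stated time of 48 h, tested at 0.2 uM (on this read-out higher numbers stand for a stronger effect at the one concentration tested and lower numbers for a weaker effect), compound 2 stands second highest of the three numbers, with compound 3 nearest and compound 1 furthest, both within the scatter of it. Compound 4 `O=C1C(=O)N(CC(CO)NCCCNc2ccnc3cc(Cl)ccc23)c2ccc(F)cc21` differs from compound 2 in one place: fluoro in place of chloro on an aromatic carbon. Within the data shown here, the only measured step at this place is a number 2 percentage points lower from compound 1 to compound 2 (within the scatter), which lies within the scatter. Among the measured compounds shown here, compound 3 carries fluoro at the same place but also a longer chain, so no single step bears on it; in this assay compound 3 gives -1%. Compound 4 is therefore expected to show no step beyond the scatter, no change at the digits printed from compound 2 to compound 4 (within the scatter). The estimate for compound 4 in this assay is 0%, ranging from -8% to 8%.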

Compound 4, a percentage reported as inhibition, at one concentration (the size of the read-out at that concentration, not a potency): -2%
Compound 4: middle estimate off by 2 percentage points, on the high side; the range from low to high includes it.
By their numbers in this assay, from the lowest: compounds 4, 3, 2 and 1 (each within the scatter of the next).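

In this assay, fluoro in place of chloro gives a number 2 percentage points lower from compound 2 to compound 4 (within the scatter), and fluoro in place of hydrogen gives a number 4 percentage points lower from compound 1 to compound 4 (within the scatter). Hydrogen, chloro and fluoro on this aromatic carbon therefore cannot be told apart in this read-out, even across the two halogens. Nothing given here accounts for these numbers.

On these data alone, it remains open whether a larger or differently built group at this place, such as trifluoromethyl, an amine or a carboxylic acid, would move the number beyond the scatter. The single concentration also leaves open whether these three groups would differ at other concentrations.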